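Ring exchange on compound 1: working notes

The source may report more compounds than this note shows. Statements on the series, on what has been measured and on what is new or still open speak of the compounds shown alone.

- compound 1 `CC(C)C(c1ccc(-c2ccc3cccc(F)c3c2)[nH]c1=O)N1CCCCS1(=O)=O`: 0.373 h
- compound 2 `CCn1ncc2c(F)cc(-c3ccc(C(CC)(CC)c4nnc(C)[nH]4)c(=O)[nH]3)cc21`: > 3 h (a limit of the assay, not a number)
- compound 3 `CCn1ncc2c(F)cc(-c3ccc(C(CC)(CC)c4nncn4C)c(=O)[nH]3)cc21`: 2.67 h

All three values come from an ADME assay on microsomes from liver (Homo sapiens) for metabolic stability; a lower number here means that the compound disappears faster, a higher number that the compound lasts longer. Among the two actual numbers, compound 1 is the lower at 0.373 h, and the gap up to compound 3 lies beyond the scatter.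

Compound 4 `CC(C)C(c1ccc(-c2ccc3cccc(F)c3c2)[nH]c1=O)N1CCCCC1=O` keeps the core of compound 1 and carries 2-oxopiperidin-1-yl on the same saturated chain carbon: a group of 7 heavy atoms (5 carbon, 1 nitrogen, 1 oxygen; one six-membered non-aromatic ring with 1 hetero atom) in place of a group of 8 heavy atoms (4 carbon, 1 nitrogen, 2 oxygen, 1 sulfur; one six-membered non-aromatic ring with 2 hetero atoms), on a saturated chain carbon bound to an aromatic carbon and a saturated chain carbon.

Going by the values given here, the only measured step is an at least 1.1-fold lower number from compound 2 to compound 3 (0.05 log units; that floor lies within the scatter). It exchanges a different group on a different core, and it is bounded by a limit, so it gives no size for this change. Among the compounds with values here, no measured compound pair covers the group exchanged here. The starting point therefore remains compound 1 at 0.373 h, with no shift beyond the scatter expected in this assay.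

The expected change is a 1.1-fold higher number from compound 1 to compound 4 (0.03 log units; within the scatter).

For compound 4 the estimated half-life is 0.4 h, with an expected range from 0.15 h to 1 h.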

Compound 4, half-life: 0.183 h
Beside the measured number, compound 4's estimate is 2.2-fold (0.34 log units) above it; the range from low to high includes it.
By their numbers in this assay, from the lowest: compound 4; then compound 1; then compound 3. At a limit, above all of these: compound 2.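

In this assay, the exchange of the sulfur-bearing ring for 2-oxopiperidin-1-yl gives a 2.0-fold lower number from compound 1 to compound 4 (0.31 log units; beyond the scatter) on the saturated chain carbon bound to an aromatic carbon and a saturated chain carbon. Going by these compounds alone, this is the first measured size for a change at this place on the core of compound 1, and it shows that the number responds to the ring held there. The data shown give no cause for this step and no measured property of either ring.

Only these two rings are shown at this place, so a piperidine without the carbonyl, an open-chain amide or a carboxylic acid on the same carbon remains open in this assay. Also open, as far as these compounds go, is whether the same exchange would give a step of like size on the core of compound 2 and compound 3.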